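A few compounds are considered here, and "the series" means these few. Any claim that something is new, unique, unknown or untested is made for them only; others in the source may bear on it.

Measured compounds:
compound 1 `CNc1nc(-c2cn(Cc3cccc(OC)c3)nn2)nc2c1ncn2[C@@H]1O[C@H](CO)[C@@H](O)[C@H]1O` gives 86.1 nM
compound 2 `CNc1nc(-n2cc(-c3ccccn3)nn2)nc2c1ncn2[C@@H]1O[C@H](CO)[C@@H](O)[C@H]1O` gives 10.3 nM
compound 3 `CNc1nc(-c2cn(Cc3cccc(Cl)c3)nn2)nc2c1ncn2[C@@H]1O[C@H](CO)[C@@H](O)[C@H]1O` gives 81.1 nM

In an assay on CHO cells for displacement of a labelled ligand from adenosine receptor A3 (Homo sapiens) (a higher number here means a weaker inhibitor, a lower number a stronger inhibitor), compound 2 stands lowest of the three; compound 3 lies a good deal higher, and compound 1 higher still, both gaps beyond the scatter. Compound 4 `CNc1nc(-n2cc(Cc3ccccc3)nn2)nc2c1ncn2[C@@H]1O[C@H](CO)[C@@H](O)[C@H]1O` has not yet been measured. It differs from compound 2 in one respect: benzyl in place of pyridin-2-yl on an aromatic carbon. Within the data shown here, none of the measured steps matches this change. Among the measured compounds shown here, the only step at hand, a 1.1-fold lower number from compound 1 to compound 3 (0.03 log units; within the scatter), concerns a substituent on a benzyl group and stays within the scatter. Compounds 1 and 3 both carry a benzyl-type group, though attached differently to their five-membered aromatic ring, and both give numbers well above compound 2, whose pyridin-2-yl gives the lowest value. On that basis compound 4 is expected to move upward from compound 2, a step of a 3.9-fold higher number from compound 2 to compound 4 (0.59 log units; beyond the scatter), though the different point of attachment in compounds 1 and 3 leaves this uncertain. Compound 4 is estimated at 40 nM, in a range from 12 nM to 130 nM.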

Compound 4, inhibition constant: 9.5 nM
Compound 4: the middle estimate sits 4.2-fold (0.62 log units) above what was measured, and the stated range ends above it.
By their numbers in this assay, from the lowest: compounds 4 and 2 (each within the scatter of the next); then compounds 3 and 1 (each within the scatter of the next).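

In this assay, benzyl in place of pyridin-2-yl on this aromatic carbon gives a 1.1-fold lower number from compound 2 to compound 4 (0.04 log units; within the scatter). At this position, then, the ring nitrogen and the hydrogen-bond acceptor of pyridin-2-yl can be lost, and a carbon-only aromatic ring carried on a benzyl group can enter, with no change beyond the scatter. Nothing available accounts for this lack of change.

The compounds shown leave open whether an aminomethyl group, a carboxylic acid or a longer chain such as hexyl on this carbon would also leave the number within the scatter of compound 2. They also leave open whether a chloro or methoxy group on the benzyl ring of compound 4 would do the same.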